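The source may report more compounds than this note shows. Statements on the series, on what has been measured and on what is new or still open speak of the compounds shown alone.

Measured compounds:
- compound 2, `CO[C@H]1O[C@H](COc2ccc3c(c2)CCCC3)[C@@H](O)[C@H](O)[C@H]1Oc1ccc(OC2CCCCC2)cc1`: 20000 nM
- compound 3, `CO[C@H]1O[C@H](COc2ccc(OC3CCCCC3)cc2)[C@@H](O)[C@H](O)[C@H]1Oc1ccc(C(C)C)cc1`: 25000 nM
- compound 1, `CO[C@H]1O[C@H](COc2cccc3c2CCCC3)[C@@H](O)[C@H](O)[C@H]1Oc1ccc(OC2CCCCC2)cc1`: "not determined" (no result reported)

All three share one core, a sugar-like ring carrying two aryl ethers, and differ only in the groups on those aryl rings. In a functional assay on MDA-MB-231 cells (Homo sapiens) for cytotoxicity, read by MTT assay, with a stated time of 48 h (on this read-out lower numbers stand for an effect already at smaller amounts and higher numbers for an effect only at larger amounts of compound), compound 3 gives 25000 nM and compound 2 gives 20000 nM; the two values lie within the usual scatter of each other, so neither can be called more or less potent. For compound 1 no number was reported in this assay. Compound 3 thus sits among the measured values without standing apart from them.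

Compound 4, `CO[C@H]1O[C@H](COc2ccc(OC3CCCCC3)cc2)[C@@H](O)[C@H](O)[C@H]1Oc1ccc(OC2CCCCC2)cc1`, differs from compound 3 in one place: cyclohexyloxy in place of isopropyl on an aromatic carbon. The resulting molecule carries cyclohexyloxy on both aryl rings, and compound 2 already shows that a cyclohexyloxy group on the second ring goes with a value of 20000 nM. Among the measured compounds shown here, no measured pair shows this exact change, so the step can only be estimated; the expectation is a step from compound 3 to compound 4 of a 1.3-fold lower number from compound 3 to compound 4 (0.10 log units; within the scatter), that is, nothing beyond the scatter. Compound 4 is therefore expected to give about 20000 nM in this assay, estimated within 8000 nM to 50000 nM.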

Compound 4, half-maximal effective concentration: 20000 nM
Beside the measured number, compound 4's estimate shows no gap at the digits printed; measured number inside the range.
By their numbers in this assay, from the lowest: compounds 2, 4 and 3 (each within the scatter of the next).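

Among the compounds shown here, replacing isopropyl with cyclohexyloxy on this aromatic carbon, para to a large group, is the first change in a single place that can be read in this assay: it gives a 1.3-fold lower number from compound 3 to compound 4 (0.10 log units; within the scatter). At this position, then, a group with a six-membered non-aromatic ring and a hydrogen-bond acceptor reads the same as the smaller, ring-free isopropyl, within the scatter of the assay. Nothing measured here offers an explanation for this result.

On these data alone, both groups compared are uncharged and carry no hydrogen-bond donor, so it remains open whether an amine or a carboxylic acid at this position would give a number clearly apart from these. Also open, as far as these compounds go, is whether a much smaller group, such as a single fluorine atom, would read the same.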